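The compounds below may be only part of what the source reports. "The series", "measured", "known", "first", "only" and "open" are said of these compounds alone.

Three compounds that share one core and differ only in the group on the amine nitrogen in a ring of the six-membered non-aromatic ring with two nitrogen have been measured. In an assay on CHO cells for displacement of a labelled ligand from adenosine receptor A1 (Homo sapiens), read by scintillation counting, with a stated time of 120 min, tested at 10 uM (on this read-out higher numbers stand for more inhibition at the one concentration tested (going by the name of the read-out) and lower numbers for less inhibition), compound 1 `Nc1scc(CN2CCN(c3ccc(F)cc3Cl)CC2)c1C(=O)c1ccc(Cl)cc1` gives 0%. In this assay compound 2 `Nc1scc(CN2CCN(c3ccc(Cl)cc3F)CC2)c1C(=O)c1ccc(Cl)cc1` gives 0%, and compound 3 `Nc1scc(CN2CCN(c3cccnc3)CC2)c1C(=O)c1ccc(Cl)cc1` gives 0%. The steps among them are no change at the digits printed from compound 1 to compound 2 (within the scatter), no change at the digits printed from compound 1 to compound 3 (within the scatter) and no change at the digits printed from compound 2 to compound 3 (within the scatter), so compound 3 stands level with compounds 1 and 2 at the digits reported, with nothing separating any of the three. Compound 4 `Nc1scc(CN2CCN(c3cccc4ccccc34)CC2)c1C(=O)c1ccc(Cl)cc1` has not yet been measured; it differs from compound 3 by naphthalen-1-yl in place of pyridin-3-yl on an amine nitrogen in a ring. All three measured steps bear on this change, since each swaps the group on the same ring nitrogen, and each of them was flat. On that basis compound 4 is expected to show no step beyond the scatter, the estimated step being a number 3 percentage points higher from compound 3 to compound 4 (within the scatter). Compound 4 is therefore estimated at 3%, with a range from 0% to 15%. On these data alone, nothing in the measured set points to a different outcome, though the move to naphthalen-1-yl itself is untested here.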

Compound 4, a percentage reported as inhibition, at one concentration (the size of the read-out at that concentration, not a potency): 1%
Beside the measured number, compound 4's estimate is 2 percentage points above it; the measured number falls inside the stated range.
By their numbers in this assay, from the lowest: compounds 1, 2, 3 and 4 (each within the scatter of the next).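

In this assay, going by these compounds alone, the earlier compounds carried a single aromatic ring on the amine nitrogen in a ring, whereas compound 4 carries naphthalen-1-yl, with 2 six-membered aromatic rings of carbon only, and the result is a number 1 percentage points higher from compound 3 to compound 4 (within the scatter) and a number 1 percentage points higher from compound 2 to compound 4 (within the scatter) and a number 1 percentage points higher from compound 1 to compound 4 (within the scatter) as well. This position therefore now spans a wider range of groups without any separation at the one concentration tested: going from 6 to 10 heavy atoms and from 1 hydrogen-bond acceptor to 0 does not separate compound 4 from the two halogenated phenyl compounds or from the pyridin-3-yl compound. Nothing measured here offers a reason for this flat picture.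

The four compounds leave open whether any group on this ring nitrogen can give a reading beyond the scatter, since each of them places an aromatic ring directly on it, and a benzyl group, a longer chain ending in an amine or a chain bearing a carboxylic acid would probe something they do not. On these data alone, it also remains open whether the same flatness would hold with a methoxy group in place of the chlorine on the shared core.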